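Dimethylamino in place of 4-methylpiperazin-1-yl: working notes

The source may report more compounds than this note shows. Statements on the series, on what has been measured and on what is new or still open speak of the compounds shown alone.

In a functional assay on EBC-1 cells (Homo sapiens) for inhibition, read by sulforhodamine B assay, with a stated time of 72 h (on this read-out lower numbers stand for stronger inhibition and higher numbers for weaker inhibition), compound 1 (`CN1CCN(CCCCCOC(=O)Nc2cccc(Cn3nc(-n4ccc5ccc(F)cc54)ccc3=O)c2)CC1`) gives <= 1000 nM, which is a limit and not a number. Compound 2 (`CN(C)CCCOC(=O)Nc1cccc(Cn2nc(-n3ccc4ccc(F)cc43)ccc2=O)c1`) gives <= 1000 nM, which is also a limit. Within the data shown here, the series so far therefore offers only (the limit of <= 1000 nM in this assay, at which 2 of the 2 values shown sit), and compound 1 has no exact standing within it.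

Compound 3 (`CN(C)CCCCCOC(=O)Nc1cccc(Cn2nc(-n3ccc4ccc(F)cc43)ccc2=O)c1`) differs from compound 1 as follows: dimethylamino in place of 4-methylpiperazin-1-yl on a saturated chain carbon, five bonds along the chain from an oxygen next to a carbonyl group. In words, dimethylamino stands in place of 4-methylpiperazin-1-yl on a saturated chain carbon, five bonds along the chain from an oxygen next to a carbonyl group.

Among the measured compounds shown here, the one measured step that bears on this is a step that the two limits leave unreadable from compound 1 to compound 2. It also brings in dimethylamino, but its size cannot be read, so it offers no size or direction to carry over. Without a readable step, no change beyond the scatter is expected in this assay, and no direction is favoured. The expected step is a step that the limit leaves unreadable from compound 1 to compound 3. For compound 3 the estimated value is 500 nM. The expected range for compound 3 runs from 80 nM to 1500 nM.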

Compound 3, half-maximal inhibitory concentration: <= 100 nM
Compound 3: no number, only a limit; the forecaster's own chance of this, stated with the estimate: 45%; at least 5.0-fold (0.69 log units) between middle value and limit.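

In this assay compound 3 gives <= 100 nM, which is a limit, and compound 1 and compound 2 also stand only as limits, so no step among these three compounds can be read. The compounds shown leave open the size and direction of the change from 4-methylpiperazin-1-yl to dimethylamino on this chain.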